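A Nitrile Added to the Methoxyphenyl Arm

The source may hold more compounds than are shown below. What is called first, only, known or untested is meant among the compounds shown, and "the series" means these compounds.

Measured compounds:
compound 1, `CCSc1sc(-n2nc(C)c(Cc3ccccc3[N+](=O)[O-])c2C(=O)O)nc1-c1ccc(Cl)c(Cl)c1`: 59000 nM
compound 2, `Cc1c(-c2cc(Cl)cc(Cl)c2)c(C(=O)O)nn1-c1nc(-c2cnn(C)c2)c(SC(C)C)s1`: "not active" (no number reported)
compound 3, `COc1ccc(-c2c(C)nn(-c3nc(-c4ccc(Cl)c(Cl)c4)c(SC(C)C)s3)c2C(=O)O)cc1`: 2100 nM

In a functional assay on BJAB cells (Homo sapiens) for antiproliferative activity, with a stated time of 4 days (on this read-out higher numbers stand for an effect only at larger amounts of compound and lower numbers for an effect already at smaller amounts), compound 1 gives 59000 nM, while compound 3 gives 2100 nM. For compound 2 the result was given only as "not active" (no number reported), with no number. Among the two numbers, compound 3 stands lowest, and compound 1 lies beyond the scatter above it. Compound 4, `COc1cc(C#N)cc(-c2c(C)nn(-c3nc(-c4ccc(Cl)c(Cl)c4)c(SC(C)C)s3)c2C(=O)O)c1`, differs from compound 3 in one place: 3-cyano-5-methoxyphenyl in place of 4-methoxyphenyl on an aromatic carbon. For the measured compounds named here, no measured pair shows the effect of this change, so a step of modest size, possibly within the scatter and leaning toward a higher number, is expected as a 1.4-fold higher number from compound 3 to compound 4 (0.15 log units; within the scatter). Compound 4 is estimated at 3000 nM, with a range from 700 nM to 15000 nM.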

Compound 4, half-maximal effective concentration: 5200 nM
Compound 4: the middle estimate sits 1.7-fold (0.24 log units) below what was measured, within the range that was stated.
By their numbers in this assay, from the lowest: compound 3; then compound 4; then compound 1.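

In this assay, placing 3-cyano-5-methoxyphenyl where 4-methoxyphenyl stood gives a 2.5-fold higher number from compound 3 to compound 4 (0.39 log units; beyond the scatter), a modest step but one beyond the usual scatter. For the compounds shown here, this is the first single-place comparison at this position, and it shows that the larger aryl group bearing a nitrile still gives a measurable number. No measurement available here explains the step. Since the change both adds the nitrile and alters the methoxy placement, the two contributions remain unseparated. As far as these compounds go, how a phenyl ring carrying an amine or a hydroxy group would behave here also remains open.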